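Swapping a nitrile for methylsulfanyl on an inactive biaryl

The source may report more compounds than this note shows. Statements on the series, on what has been measured and on what is new or still open speak of the compounds shown alone.

Measured so far in a functional assay on RKE cells for antagonist activity at Vasoactive intestinal polypeptide receptor 1 (Rattus norvegicus), read by HTRF and cAMP accumulation, with stated times of 10 min and 30 min; a higher number here means a weaker inhibitor, a lower number a stronger inhibitor:
Compound 1 `CC(C)c1cc(C(C)(C)C)cc(-c2cccc(C#N)c2)c1CO` gives > 50000 nM.
Compound 2 `CC(C)c1cc(C(C)(C)C)cc(-c2ccc(-c3ccccc3)cc2)c1CO` gives 680 nM.
Compound 3 `CC(C)c1cc(C(C)(C)C)cc(-c2ccc(Cl)cc2)c1CO` gives 290 nM.

Compound 1 gives only (the limit of > 50000 nM in this assay, at which 1 of the 3 values shown sits), so it is a limit of the assay and not a measured number. Among the compounds with a measured number, compound 3 sits at 290 nM and compound 2 at 680 nM; the step of a 2.3-fold lower number from compound 2 to compound 3 (0.37 log units; beyond the scatter) is the only single change with a measured size, and it concerns a different substituent swap on the same outer ring.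

Compound 4 `CSc1cccc(-c2cc(C(C)(C)C)cc(C(C)C)c2CO)c1` differs from compound 1 by methylsulfanyl in place of cyano on an aromatic carbon. For the measured compounds named here, no measured step covers this exact exchange. What the data do show is that the nitrile-bearing compound 1 is out of range, while a small halogen in compound 3 gives a measured value; the direction of the step from compound 1 is therefore expected to be toward a lower number, though its size is uncertain. Compound 4 is expected to give 3000 nM, with a range from 400 nM to 30000 nM, which would mean an estimated step of an at least 16-fold lower number from compound 1 to compound 4 (1.22 log units; beyond the scatter).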

Compound 4, half-maximal inhibitory concentration: 170 nM
Compound 4: the middle estimate sits 18-fold (1.25 log units) above what was measured; measured number outside the range, below it.
By their numbers in this assay, from the lowest: compounds 4 and 3 (each within the scatter of the next); then compound 2. At a limit, above all of these: compound 1.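

At this aromatic carbon, meta to a large group, in this assay, methylsulfanyl in place of cyano gives an at least 290-fold lower number from compound 1 to compound 4 (2.46 log units; beyond the scatter). Compound 1 carries only a limit of the assay and not a number: the limit of > 50000 nM in this assay, at which 1 of the 4 values shown sits. The earlier compounds shown here left open whether a group at this position could give a measured number at all; compound 4 shows that it can, and that two groups with the same count of heavy atoms and of hydrogen-bond acceptors can differ widely here.

With only these two groups shown at this position, the data cannot tell whether the sulfur atom itself matters. From the compounds shown here alone, how a methoxy group, with oxygen in place of sulfur, or an amine would behave at the same carbon remains open.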